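This account rests on a few compounds, and the source may have more. Where it says the series, first, only, none or still open, it means among the compounds named here.

Of the compounds shown here, three built on a shared core have been measured in an assay on isolated protein for inhibition of DNA topoisomerase 1 (Homo sapiens), with a stated time of 30 min, tested at 100 uM; a higher number here means a stronger effect of the compound at the concentration tested, a lower number a weaker effect. Compound 1 `Oc1ccc(-c2cc(-c3ccc(Cl)cc3)nc(-c3cccnc3)c2)cc1` gives 18.8%, compound 2 `Oc1ccc(-c2cc(-c3cccc(Cl)c3)nc(-c3ccccn3)c2)cc1` gives 59.4%, and compound 3 `Oc1cccc(-c2cc(-c3ccc(Cl)cc3)nc(-c3cccnc3)c2)c1` gives 2.8%. Compound 2 stands highest of the three, and its gaps to compound 1 and to compound 3 are both beyond the scatter. How the core of compound 1 differs from the core of compound 2 is not broken down here.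

Compound 3 arises from compound 1 by 3-hydroxyphenyl in place of 4-hydroxyphenyl on an aromatic carbon, and that change lowered inhibition in this assay, a number 16 percentage points lower from compound 1 to compound 3 (beyond the scatter). Compound 4 `Oc1cccc(-c2cc(-c3cccc(Cl)c3)nc(-c3ccccn3)c2)c1`, not yet measured, arises from compound 2 by the same kind of change, (3-hydroxyphenyl in place of 4-hydroxyphenyl on an aromatic carbon), though the surroundings differ: in compound 2 the place is meta to a 3-chlorophenyl group and meta to a pyridin-2-yl group, in compound 1 meta to a 4-chlorophenyl group and meta to a pyridin-3-yl group.

Resting only on the step from compound 1 to compound 3, the expected step is a number 17.4 percentage points lower from compound 2 to compound 4 (beyond the scatter). Compound 4 is therefore expected to give about 42% in this assay, plausibly between 20% and 60%.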

Compound 4, a percentage reported as inhibition, at one concentration (the size of the read-out at that concentration, not a potency): 0.4%
For compound 4 the middle estimate is 41.6 percentage points above the measured one; the whole stated range lies above it.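

In this assay, putting 3-hydroxyphenyl in place of 4-hydroxyphenyl lowered inhibition once more, the new result being a number 59 percentage points lower from compound 2 to compound 4 (beyond the scatter). The direction of the change carried over from one core to the other, but its size did not: the same change on two cores in this assay, a number 16 percentage points lower (beyond the scatter) from compound 1 to compound 3 and a number 59 percentage points lower (beyond the scatter) from compound 2 to compound 4, 43 percentage points apart, beyond the scatter of two such steps. Among the compounds shown here, with only two pairs, this does not show which difference between the cores goes with the larger drop, the chlorophenyl group or the pyridinyl group, so a step measured on one core gave the direction here but not a dependable size for the other.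

Still open, going by these compounds, is how a core would behave that pairs 3-chlorophenyl with pyridin-3-yl, or 4-chlorophenyl with pyridin-2-yl, since either pairing would pull apart the two differences between these cores. Also open, on these data alone, is how inhibition would respond if a methoxy group or an amine stood in place of the hydroxyl group on the phenyl ring.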